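Methoxybenzyl Replaces Thiophene on the Shared Core

The source may hold more compounds than are shown below. What is called first, only, known or untested is meant among the compounds shown, and "the series" means these compounds.

Among the three measured compounds, compound 3 `C=C(Br)C(=O)Nc1cccc(-c2cn3nc(-c4cccs4)sc3n2)c1` gives the lowest number, with 170 nM in a functional assay on L1210 cells (Mus musculus) for inhibition, read by cell counting, with a stated time of 2 days; on this read-out higher numbers stand for weaker inhibition and lower numbers for stronger inhibition. Compound 2 `C=C(Br)C(=O)Nc1cccc(-c2cn3nc(-c4ccccc4)sc3n2)c1` gives 600 nM, and compound 1 `C=C(Br)C(=O)Nc1cccc(-c2cn3nc(-c4ccc(CC)cc4)sc3n2)c1` gives 2200 nM. All three steps between them lie beyond the scatter: a 3.5-fold lower number from compound 2 to compound 3 (0.55 log units; beyond the scatter), a 3.7-fold lower number from compound 1 to compound 2 (0.56 log units; beyond the scatter), and a 13-fold lower number from compound 1 to compound 3 (1.11 log units; beyond the scatter).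

Compound 4 `C=C(Br)C(=O)Nc1cccc(-c2cn3nc(Cc4ccc(OC)cc4)sc3n2)c1` differs from compound 3 in a single place: 4-methoxybenzyl in place of thiophen-2-yl on an aromatic carbon. Two of the measured steps bear on this change. The step of a 3.5-fold lower number from compound 2 to compound 3 (0.55 log units; beyond the scatter) shows that a six-membered carbon ring in this position gave a higher number than the thiophen-2-yl group, so returning to a six-membered ring points toward a higher number. The step of a 3.7-fold lower number from compound 1 to compound 2 (0.56 log units; beyond the scatter) shows that adding an ethyl to that six-membered ring raised the number further, and compound 4 also carries a substituent on its six-membered ring, the methoxy. Going by the values given here, the methylene that links the ring to the core in compound 4 has no counterpart among the measured compounds, so its effect is unknown. Compound 4 is therefore expected to give a higher number than compound 3, estimated at 900 nM with a range from 250 nM to 3500 nM. This estimate corresponds to an expected 5.3-fold higher number from compound 3 to compound 4 (0.72 log units; beyond the scatter).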

Compound 4, half-maximal inhibitory concentration: 1400 nM
Compound 4: middle estimate off by 1.6-fold (0.19 log units), on the low side, within the range that was stated.
By their numbers in this assay, from the lowest: compound 3; then compound 2; then compounds 4 and 1 (each within the scatter of the next).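

In this assay, placing 4-methoxybenzyl on this aromatic carbon gives an 8.2-fold higher number from compound 3 to compound 4 (0.92 log units; beyond the scatter) and so leaves compound 3 with the lowest number of the four. A six-membered aromatic ring carrying a substituent and joined through a methylene also falls short of plain phenyl, with a 2.3-fold higher number from compound 2 to compound 4 (0.37 log units; beyond the scatter) as the step, whereas a 1.6-fold lower number from compound 1 to compound 4 (0.20 log units; within the scatter) shows that 4-methoxybenzyl and 4-ethylphenyl cannot be told apart at this position, even though the two groups differ in both the methylene and the substituent. No supporting evidence is available to explain these differences.

Going by these compounds, how much of the change belongs to the methylene and how much to the methoxy remains open, and a plain benzyl or a 4-methoxyphenyl group on this carbon would separate the two contributions. On these data alone, it is also open whether the low number of compound 3 is particular to thiophen-2-yl or extends to another five-membered aromatic ring such as furan-2-yl.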